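Compound 3: pyridin-3-yl to 6-aminopyridin-3-yl

This account rests on a few compounds, and the source may have more. Where it says the series, first, only, none or still open, it means among the compounds named here.

In a physicochemical assay for solubility, read by LC-MS, in phosphate buffer, with a stated time of 24 h, at pH 6.8 (a lower number here means a less soluble compound, a higher number a more soluble compound), compound 1 (`C[C@H](NC(=O)c1ncccn1)c1ccc(NC(=O)N2CC(c3cccnc3)C2)cc1`) gives 930000 nM. Compound 2 (`C[C@H](NC(=O)C1CCOCC1)c1ccc(NC(=O)N2CC(c3cccnc3)C2)cc1`) gives 380000 nM, the lower of the two numbers and beyond the scatter from compound 1.

Compound 3 (`C[C@H](NC(=O)C1CCOCC1)c1ccc(NC(=O)N2CC(c3ccc(N)nc3)C2)cc1`) keeps the oxan-4-yl of compound 2 and changes a different place: pyridin-3-yl becomes 6-aminopyridin-3-yl, amino in place of hydrogen on an aromatic carbon.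

Within the data shown here, only one measured step exists: a 2.4-fold lower number from compound 1 to compound 2 (0.39 log units; beyond the scatter), with oxan-4-yl in place of pyrimidin-2-yl on a carbonyl carbon. That step is modest and leaves the pyridin-3-yl untouched, so it bears on the new change only indirectly, as a guide to how far one substitution has moved the number in this series. Among the measured compounds shown here, no measured compound carries the amino group, and the data therefore give no direction. No step beyond the scatter is expected in this assay, though the range stays wide on both sides.

The expected change is a 1.1-fold lower number from compound 2 to compound 3 (0.04 log units; within the scatter). Compound 3 is estimated at 350000 nM, with an expected range of 120000 nM to 900000 nM.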

Compound 3, solubility: 310000 nM
The estimate for compound 3 lay 1.1-fold (0.05 log units) above the measured number; measured number inside the range.
By their numbers in this assay, from the lowest: compounds 3 and 2 (each within the scatter of the next); then compound 1.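

In this assay, amino in place of hydrogen on an aromatic carbon, next to the ring nitrogen and para to a large group, gives a 1.2-fold lower number from compound 2 to compound 3 (0.09 log units; within the scatter), so this assay does not separate the two compounds. Among these compounds, this is the first reading at the pyridine end of the series, as the earlier step, a 2.4-fold lower number from compound 1 to compound 2 (0.39 log units; beyond the scatter), concerned the group on the carbonyl carbon and left the pyridin-3-yl untouched. Among the steps shown, only that change on the carbonyl carbon lies beyond the scatter, while this single substitution on the aromatic ring stays within it, and no available evidence accounts for either reading.

Going by these compounds, the amino step has been read only with oxan-4-yl on the carbonyl carbon, so it remains open whether 6-aminopyridin-3-yl gives a step of similar size alongside the pyrimidin-2-yl of compound 1. On these data alone, it is also open whether a dimethylamino group, a methoxy group or a carboxylic acid in the same place would stay within the scatter of compound 2 or move beyond it.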